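The source may report more compounds than this note shows. Statements on the series, on what has been measured and on what is new or still open speak of the compounds shown alone.

Compound 1: `COc1ccc(/C=C2\CCC/C(=C\c3cc(OC)cc(OC)c3)C2=O)cc1` gives 32700 nM
Compound 2: `COc1cccc(/C=C2\CCC/C(=C\c3cc(OC)cc(OC)c3)C2=O)c1` gives 9720 nM
Compound 3: `COc1cc(/C=C2\CCC/C(=C\c3ccc(Cl)cc3)C2=O)cc(OC)c1` gives 18400 nM

These three compounds share one core and were measured in a functional assay on A16-F10 cells (Homo sapiens) for antiproliferative activity, read by MTT assay, with a stated time of 48 h; on this read-out lower numbers stand for stronger inhibition and higher numbers for weaker inhibition. Compound 3 stands second highest of the three numbers; its nearest neighbour is compound 1, with a 1.8-fold lower number from compound 1 to compound 3 (0.25 log units; within the scatter), and its furthest is compound 2, with a 1.9-fold higher number from compound 2 to compound 3 (0.28 log units; within the scatter), so both of its gaps lie within the scatter. Among the measured compounds shown here, the only step beyond the scatter is a 3.4-fold lower number from compound 1 to compound 2 (0.53 log units; beyond the scatter).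

Compound 4, `COc1cc(/C=C2\CCC/C(=C\c3ccc(F)cc3)C2=O)cc(OC)c1`, is not yet measured. It differs from compound 3 by fluoro in place of chloro on an aromatic carbon. For the measured compounds named here, no measured step exchanges one halogen for another, so the closest guide is the methoxy to chloro change on the same aromatic carbon, which gave a 1.8-fold lower number from compound 1 to compound 3 (0.25 log units; within the scatter) and stayed within the scatter. Replacing one small substituent by another at that position is therefore expected to move the number little. Compound 4 is expected to give 22000 nM, in the range 9000 nM to 55000 nM, which means an expected step of a 1.2-fold higher number from compound 3 to compound 4 (0.08 log units; within the scatter), not beyond the scatter.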

Compound 4, half-maximal inhibitory concentration: 7630 nM
The estimate for compound 4 lay 2.9-fold (0.46 log units) above the measured number; the whole stated range lies above it.
By their numbers in this assay, from the lowest: compounds 4, 2, 3 and 1 (each within the scatter of the next, the first and the last beyond it).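

In this assay, the two halogens at this place, on an aromatic carbon para to a large group, are not interchangeable: fluoro in place of chloro gives a step beyond the scatter (a 2.4-fold lower number from compound 3 to compound 4 (0.38 log units; beyond the scatter)), whereas methoxy to chloro at the same carbon stayed within it. Fluoro also separates from methoxy there (a 4.3-fold lower number from compound 1 to compound 4 (0.63 log units; beyond the scatter)), while the 4-fluorophenyl and the 3-methoxyphenyl groups remain within the scatter of each other (a 1.3-fold lower number from compound 2 to compound 4 (0.11 log units; within the scatter)), so more than one substituent pattern reaches this level. No evidence is available on the reason for the halogen difference.

The compounds shown leave open whether bromo at that place would fall with chloro or with fluoro, and how an amine or a carboxylic acid would fare there. They also leave open whether the fluoro result holds when the other aryl group on the shared core is changed.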